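A few compounds are considered here, and "the series" means these few. Any claim that something is new, unique, unknown or untested is made for them only; others in the source may bear on it.

In a physicochemical assay for solubility, read by spectrophotometry, with a stated time of 24 h, at pH 7.4 (on this read-out higher numbers stand for higher solubility and lower numbers for lower solubility), the three measured compounds are known only through limits. Compound 1 `CN(C)c1ccc(C(=O)N/N=C/c2cccc(C(=O)O)c2)cc1` gives > 70000 nM, which is a limit and not a number. Compound 2 `CN(C)c1ccc(C(=O)N/N=C/c2ccc(C(=O)O)cc2)cc1` gives > 77000 nM, also a limit. Compound 3 `CN(/N=C/c1ccc(C(=O)O)cc1)C(=O)c1ccc(N(C)C)cc1` gives > 67000 nM, again a limit. The three therefore cannot be placed in any order, and compound 3 has no number of its own to start from.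

Compound 4 `COC(=O)c1ccc(/C=N/N(C)C(=O)c2ccc(N(C)C)cc2)cc1` differs from compound 3 in one place: methyl in place of hydrogen on an oxygen next to a carbonyl group, with methyl in place of hydrogen on an oxygen next to a carbonyl group, or carboxy to methoxycarbonyl. Within the data shown here, the one measured step that comes close is a step that the two limits leave unreadable from compound 2 to compound 3. It also brought in a methyl, but on an amide-type nitrogen, and it sets no scale. Among the measured compounds shown here, no measured compound carries the methoxycarbonyl group. Even so, a downward move is expected in this assay, and the estimated change is an at least 3.3-fold lower number from compound 3 to compound 4 (0.52 log units; beyond the scatter). For compound 4 the estimated value is 20000 nM, with an expected range of 4000 nM to 70000 nM.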

Compound 4, solubility: 1400 nM
For compound 4 the middle estimate is 14-fold (1.15 log units) above the measured one; measured number below the stated range.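

In this assay, among these compounds, the change from carboxy to methoxycarbonyl gives an at least 47-fold lower number from compound 3 to compound 4 (1.67 log units; beyond the scatter), the first step in these compounds whose size can be read at all, since the steps among compounds 1, 2 and 3 cannot be read. Compound 4 is also the first compound shown with a number and not a limit, so the read-out does respond to a change at this oxygen next to a carbonyl group, and the response is large. The step has only a minimum size, as compound 3 stands at a limit and not a number: the limit of > 67000 nM in this assay, at which 1 of the 4 values shown sits.

From the compounds shown here alone, whether a longer chain on that oxygen, such as ethyl, or a primary amide in place of methoxycarbonyl would read like compound 4 stays open. So does whether the same change would give a step of similar size on the core of compound 1 or compound 2.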